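Swapping the ring on the sulfur: from tetrazole to thiadiazole

A few compounds are considered here, and "the series" means these few. Any claim that something is new, unique, unknown or untested is made for them only; others in the source may bear on it.

Three compounds share one core and differ only in the aromatic ring attached to a sulfur. Compound 1 `Cc1ccc2oc(SCC(=O)Nc3ccc(-c4nc(-c5ccccc5)c(-c5ccccc5)n4C)cc3)nc2c1` carries a 5-methyl-1,3-benzoxazol-2-yl there; in a functional assay on HT-29 cells (Homo sapiens) for cytotoxicity, read by MTT assay, with a stated time of 24 h, tested at 1.6 ug/mL (on this read-out lower numbers stand for a weaker effect and higher numbers for a stronger effect at the one concentration tested), compound 1 gives 15.5%. Compound 2 `Cn1cnnc1SCC(=O)Nc1ccc(-c2nc(-c3ccccc3)c(-c3ccccc3)n2C)cc1` carries a 4-methyl-4H-1,2,4-triazol-3-yl and gives 40.8%. Compound 3 `Cn1nnnc1SCC(=O)Nc1ccc(-c2nc(-c3ccccc3)c(-c3ccccc3)n2C)cc1` carries a 1-methyl-1H-tetrazol-5-yl and gives 49.8%, the highest of the three numbers, though its gap to compound 2 is within the scatter, so no order between those two can be read.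

Compound 4 `Cc1nnc(SCC(=O)Nc2ccc(-c3nc(-c4ccccc4)c(-c4ccccc4)n3C)cc2)s1` is the next step. Its change from compound 3 is 5-methyl-1,3,4-thiadiazol-2-yl in place of 1-methyl-1H-tetrazol-5-yl on a sulfur. For the measured compounds named here, no measured step tests this exact exchange. The steps of a number 34.3 percentage points higher from compound 1 to compound 3 (beyond the scatter) and a number 25.3 percentage points higher from compound 1 to compound 2 (beyond the scatter) show that moving from the large two-ring group to a small five-membered ring made a clear difference, while a number 9 percentage points higher from compound 2 to compound 3 (within the scatter) shows that exchanging one small five-membered ring for another stayed within the scatter. The present change is again small ring for small ring, so the expected step is a number 9.8 percentage points lower from compound 3 to compound 4 (within the scatter). Compound 4 is therefore estimated at 40%, with a range from 20% to 60%.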

Compound 4, a percentage reported as activity, at one concentration (the size of the read-out at that concentration, not a potency): 39.9%
Compound 4: the middle estimate sits 0.1 percentage points above what was measured, and the stated range covers the measured number.
By their numbers in this assay, from the lowest: compound 1; then compounds 4, 2 and 3 (each within the scatter of the next).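

The 5-methyl-1,3,4-thiadiazol-2-yl puts a sulfur into the ring and has 3 hetero atoms in place of 4, yet in this assay the result is a number 9.9 percentage points lower from compound 3 to compound 4 (within the scatter) and a number 0.9 percentage points lower from compound 2 to compound 4 (within the scatter), so these three small five-membered rings on the sulfur cannot be told apart. Against the two-ring group, the result is a number 24.4 percentage points higher from compound 1 to compound 4 (beyond the scatter), which makes a third small ring that stands clearly apart from the 5-methyl-1,3-benzoxazol-2-yl. Nothing at hand explains why these small rings read alike.

The compounds shown leave open whether the gap to compound 1 comes from the second ring itself or from the atoms of the first ring. They also leave open what a six-membered ring such as pyridine, or an open butyl chain, would give on this sulfur.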